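The source may report more compounds than this note shows. Statements on the series, on what has been measured and on what is new or still open speak of the compounds shown alone.

Series notes. Compound 2 `COc1cccc(-c2c(-c3ccccc3)c(-c3ccccc3)n3ccc(C#N)cc23)c1` stands with "not determined" (no result reported) in an assay for inhibition of Polyunsaturated fatty acid lipoxygenase ALOX15 (Oryctolagus cuniculus); a lower number here means a stronger inhibitor, a higher number a weaker inhibitor; one further member of the set, compound 1 `COc1ccc(COc2c(-c3ccccc3)c(-c3ccccc3)n3ccc(C#N)cc23)cc1`, likewise returned "not determined" (no result reported) in this assay. The only numeric anchor in this assay is compound 3 `N#Cc1ccn2c(-c3ccccc3)c(-c3ccccc3)c(C(=O)c3ccccc3)c2c1`, which gives 43000 nM, a weak inhibition on the shared core. Compound 4 `N#Cc1ccn2c(-c3ccccc3)c(-c3ccccc3)c(CO)c2c1` is the next member to be measured in this assay. The change from compound 2 to compound 4 is hydroxymethyl in place of 3-methoxyphenyl on an aromatic carbon. Since compound 2 carries no number, no size or direction can be expected for this step in this assay; whether it lies within or beyond the scatter cannot be said. For the measured compounds named here, the expectation for compound 4 therefore rests on the single value of compound 3 and on the small hydroxymethyl that enters. Because compound 3 gives 43000 nM on the same core, compound 4 is expected to stay in the weak region, estimated at 50000 nM, with a range from 10000 nM to 200000 nM.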

Compound 4, half-maximal inhibitory concentration: 34000 nM
Compound 4: middle estimate off by 1.5-fold (0.17 log units), on the high side; the measured number falls inside the stated range.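

In this assay, for the compounds shown here, hydroxymethyl in place of benzoyl on the aromatic carbon of the five-membered ring gives a 1.3-fold lower number from compound 3 to compound 4 (0.10 log units; within the scatter) as the first readable step at this position. Benzoyl and hydroxymethyl are therefore not told apart here, even though only one of them carries a ring, and both compounds stay in the weak region on the shared core. Steps to or from compound 1 and compound 2 cannot be read, as neither has a number in this assay.

As far as these compounds go, it remains open whether an amine, a carboxylic acid or a longer chain on this carbon would move the value beyond the scatter. From the compounds shown here alone, it is also open whether any group here can lift the shared core out of the weak region. No available evidence bears on this result.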